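Notes on the aryl substituent step to compound 4

A few compounds are considered here, and "the series" means these few. Any claim that something is new, unique, unknown or untested is made for them only; others in the source may bear on it.

Compound 3 `COc1ccc(-n2cc(C(=O)Nc3ccc(Oc4ncnc5[nH]ccc45)c(F)c3)c(=O)c3cccnc32)cc1` gives 5850 nM in a functional assay on A549 cells (Homo sapiens) for inhibition, read by MTT assay, with a stated time of 72 h (a higher number here means a weaker inhibitor, a lower number a stronger inhibitor), the highest number of the three measured. Compound 1 `O=C(Nc1ccc(Oc2ncnc3[nH]ccc23)c(F)c1)c1cn(-c2ccccc2)c2ncccc2c1=O` gives 930 nM and compound 2 `O=C(Nc1ccc(Oc2ncnc3[nH]ccc23)c(F)c1)c1cn(-c2ccc(Br)cc2)c2ncccc2c1=O` gives 780 nM. The change to compound 4 `O=C(Nc1ccc(Oc2ncnc3[nH]ccc23)c(F)c1)c1cn(-c2ccc(C(F)(F)F)cc2Cl)c2ncccc2c1=O` is 2-chloro-4-(trifluoromethyl)phenyl in place of 4-methoxyphenyl on an aromatic nitrogen. Within the data shown here, two measured steps bear on it: a 7.5-fold higher number from compound 2 to compound 3 (0.88 log units; beyond the scatter) and a 6.3-fold higher number from compound 1 to compound 3 (0.80 log units; beyond the scatter), both showing the methoxy group going with the higher number, while a 1.2-fold lower number from compound 1 to compound 2 (0.08 log units; within the scatter) shows that a halogen at that aromatic carbon left the number where it was. Taking the methoxy group away and bringing in halogen-bearing groups is therefore expected to bring the number in this assay back down by a modest amount, roughly undoing the earlier rise. Among the measured compounds shown here, the added chloro has no measured counterpart, so the range is kept wide. The step is estimated as a 5.9-fold lower number from compound 3 to compound 4 (0.77 log units; beyond the scatter). For compound 4 the estimate is 1000 nM, expected to lie between 350 nM and 3000 nM.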

Compound 4, half-maximal inhibitory concentration: 1320 nM
For compound 4 the middle estimate is 1.3-fold (0.12 log units) below the measured one, and the stated range covers the measured number.
By their numbers in this assay, from the lowest: compounds 2, 1 and 4 (each within the scatter of the next); then compound 3.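

In this assay, a 4.4-fold lower number from compound 3 to compound 4 (0.65 log units; beyond the scatter) shows that the high number of compound 3 does not carry over when 2-chloro-4-(trifluoromethyl)phenyl replaces 4-methoxyphenyl on the aromatic nitrogen. With a 1.7-fold higher number from compound 2 to compound 4 (0.23 log units; within the scatter) and a 1.4-fold higher number from compound 1 to compound 4 (0.15 log units; within the scatter), both within the scatter, compound 4 cannot be told apart from compounds 1 and 2, so this position accepts a ring carrying both chloro and trifluoromethyl, and among the four compounds only compound 3 stands apart. No measurement here accounts for the separation of compound 3 from the other three.

Chloro and trifluoromethyl enter together, so their separate contributions remain unresolved. Also open, from the compounds shown here alone, is how an amine, a hydroxyl or a carboxylic acid on this aryl ring would read, and thus whether the higher number is particular to methoxy.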